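The source may hold more compounds than are shown below. What is called first, only, known or untested is meant among the compounds shown, and "the series" means these compounds.

In a functional assay on HCT-116 cells (Homo sapiens) for inhibition, read by CCK-8 assay, with a stated time of 48 h (a higher number here means a weaker inhibitor, a lower number a stronger inhibitor), compound 1 `CCN1CCN(C(=S)SCC(=O)N(Cc2ccc(OC)cc2)c2cc(OC)c(OC)c(OC)c2)CC1` gives 7700 nM, compound 2 `COc1ccc(CN(C(=O)CSC(=S)N2CCN(Cc3ccc(C(C)(C)C)cc3)CC2)c2cc(OC)c(OC)c(OC)c2)cc1` gives 6890 nM, and compound 3 `COc1ccc(CN(C(=O)CSC(=S)N2CCc3cc(OC)ccc32)c2cc(OC)c(OC)c(OC)c2)cc1` gives 9810 nM. Compound 1 stands among these numbers without being separated from either of the other two compounds. Replacing methyl on a saturated chain carbon bound to an amine nitrogen in a ring with 4-(tert-butyl)phenyl gives a 1.1-fold lower number from compound 1 to compound 2 (0.05 log units; within the scatter). Putting 5-methoxy-2,3-dihydro-1H-indol-1-yl in place of 4-ethylpiperazin-1-yl on a thiocarbonyl carbon gives a 1.3-fold higher number from compound 1 to compound 3 (0.11 log units; within the scatter).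

Compound 4 `COc1ccc(CN(C(=O)CSC(=S)N2CCCc3cc(C)ccc32)c2cc(OC)c(OC)c(OC)c2)cc1` has not yet been measured. It carries 6-methyl-1,2,3,4-tetrahydroquinolin-1-yl in place of 4-ethylpiperazin-1-yl on a thiocarbonyl carbon. The change to compound 3 bears on it most directly, since it replaces the same group at the same place, and compound 3 shows a 1.3-fold higher number from compound 1 to compound 3 (0.11 log units; within the scatter). The change to compound 2 also alters the same end of the molecule, and compound 2 shows a 1.1-fold lower number from compound 1 to compound 2 (0.05 log units; within the scatter). No step beyond the scatter is therefore expected in this assay. The estimated step is a 1.0-fold higher number from compound 1 to compound 4 (0.02 log units; within the scatter). For compound 4 the expected value is 8000 nM, within an estimated range of 4000 nM to 15000 nM.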

Compound 4, half-maximal inhibitory concentration: 5230 nM
Compound 4: middle estimate off by 1.5-fold (0.18 log units), on the high side; low and high end bracket the measured number.
By their numbers in this assay, from the lowest: compounds 4, 2, 1 and 3 (each within the scatter of the next).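

In this assay, 6-methyl-1,2,3,4-tetrahydroquinolin-1-yl on a thiocarbonyl carbon gives a 1.5-fold lower number from compound 1 to compound 4 (0.17 log units; within the scatter), so a group with an aromatic ring of carbon only and no hydrogen-bond acceptor can take the place of 4-ethylpiperazin-1-yl without a step beyond the scatter. Set against 5-methoxy-2,3-dihydro-1H-indol-1-yl, the same group gives a 1.9-fold lower number from compound 3 to compound 4 (0.27 log units; within the scatter), so every step listed at this place, from saturated and from partly aromatic groups alike, now stays within the scatter. Nothing measured here accounts for these numbers, and no independent data bear on the result.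

As far as these compounds go, whether a simple open-chain diethylamino group or a ring bearing a carboxylic acid on a thiocarbonyl carbon would move the number beyond the scatter remains open. So does whether any change to the shared core would do so.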